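A few compounds are considered here, and "the series" means these few. Any claim that something is new, unique, unknown or untested is made for them only; others in the source may bear on it.

Measured in a functional assay on HeLa cells (Homo sapiens) for inhibition, read by CCK-8 assay, with a stated time of 72 h, tested at 2 uM; on this read-out higher numbers stand for more inhibition of growth at the one concentration tested and lower numbers for less inhibition of growth:
- compound 1 `Nc1ccccc1NC(=O)/C=C/c1ccc(CSc2ccc(C(F)(F)F)cn2)cc1`: 6.07%
- compound 2 `CC(C)(C)c1ccc(SCc2ccc(C(=O)Nc3ccccc3N)cc2)cc1`: 9.73%
- compound 3 `Nc1ccccc1NC(=O)c1ccc(CSc2ccc(F)cc2)cc1`: 27.9%

Compound 1, at 6.07%, sits at the low end of this small set. It lies within the scatter of compound 2 and beyond the scatter of compound 3, which gives 27.9%.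

The next compound to be tested is compound 4 `CC(C)(C)c1ccc(SCc2ccc(/C=C/C(=O)Nc3ccccc3N)cc2)cc1`. It keeps the core of compound 1 and carries 4-(tert-butyl)phenyl in place of 5-(trifluoromethyl)pyridin-2-yl on a sulfur.

Among the compounds with values here, only one measured step bears on this change, and only indirectly. It is a number 18.2 percentage points higher from compound 2 to compound 3 (beyond the scatter), a modest step with fluoro in place of tert-butyl on an aromatic carbon. That step leaves the compound with the tert-butyl group at the lower value. Compound 2 also has the 4-(tert-butyl)phenyl on a sulfur, and at 9.73% it gives no sign of a gain, although its core differs from that of compound 4.

No rise is therefore expected in this assay, and no step beyond the scatter is expected in either direction. The expected change is a number 1.9 percentage points higher from compound 1 to compound 4 (within the scatter). For compound 4 the estimated value is 8%, with an expected range from 1% to 20%.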

Compound 4, percent growth inhibition at one concentration: 17.5%
Compound 4: middle estimate off by 9.5 percentage points, on the low side; the range from low to high includes it.
By their numbers in this assay, from the lowest: compounds 1, 2 and 4 (each within the scatter of the next, the first and the last beyond it); then compound 3.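

In this assay, placing 4-(tert-butyl)phenyl in place of 5-(trifluoromethyl)pyridin-2-yl on the sulfur of the shared core gives a number 11.4 percentage points higher from compound 1 to compound 4 (beyond the scatter), so this position does respond to the group it carries. Until now the tert-butyl group had appeared only on the lower side of a step, in a number 18.2 percentage points higher from compound 2 to compound 3 (beyond the scatter); here it stands on the higher side, which shows that it does not go with the lower number in every comparison. The two groups have the same count of 10 heavy atoms and one six-membered aromatic ring each, so the step comes without a change in either count, and no measurement shown here accounts for it.

The ring nitrogen and the trifluoromethyl group leave together in this single exchange, so their separate shares in the step cannot be told apart, and a comparison with 4-(trifluoromethyl)phenyl on the same sulfur would bear directly on that. On these data alone, it also remains open how this core would respond to 4-fluorophenyl on the sulfur, or to a phenyl ring carrying an amine or a carboxylic acid.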